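The compounds below may be only part of what the source reports. "The series", "measured", "known", "first", "only" and "open" are said of these compounds alone.

Compound 1 `CC(=O)Nc1ccc(-n2nncc2CN2C(=O)C3(C(C#N)=C(N)Oc4c3c3nc5ccccc5nc3c3ccccc43)c3ccccc32)cc1` in a functional assay on HepG2 cells (Homo sapiens) for antiproliferative activity, read by MTT assay, with a stated time of 48 h (a higher number here means a weaker inhibitor, a lower number a stronger inhibitor), sits at the limit of > 50000 nM. Compound 2 `N#CC1=C(N)Oc2c(c3nc4ccccc4nc3c3ccccc23)C12C(=O)N(Cc1cnnn1-c1cccc(S(N)(=O)=O)c1)c1ccccc12` gives 21500 nM. Compound 3 `CC(=O)Nc1ccc(-n2nncc2CN2C(=O)C3(C(C#N)=C(N)Oc4c(N)cc5nc6ccccc6nc5c43)c3ccccc32)cc1` likewise sits at the limit of > 50000 nM.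

Compound 3 is thus not resolved by this assay; its value is a limit, one of two that share (the limit of > 50000 nM in this assay, at which 2 of the 3 values shown sit). Compound 4 `N#CC1=C(N)Oc2c(N)cc3nc4ccccc4nc3c2C12C(=O)N(Cc1cnnn1-c1cc(Cl)ccc1Cl)c1ccccc12` differs from compound 3 in one place: 2,5-dichlorophenyl in place of 4-acetamidophenyl on an aromatic nitrogen. Among the measured compounds shown here, the only measured step on this aromatic nitrogen is an at least 2.3-fold lower number from compound 1 to compound 2 (0.36 log units; beyond the scatter), and that change is a different one, so it bears only loosely on compound 4. The 2,5-dichlorophenyl group carries no donor or acceptor, unlike the groups measured so far. Compound 4 is therefore expected to remain weak, with a step of an at least 1.2-fold lower number from compound 3 to compound 4 (0.09 log units; that floor lies within the scatter) at most modest. The estimated value of compound 4 is 40000 nM, between 15000 nM and 100000 nM.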

Compound 4, half-maximal inhibitory concentration: 33100 nM
Estimate against measurement, compound 4: 1.2-fold (0.08 log units) above, within the range that was stated.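

In this assay, 2,5-dichlorophenyl in place of 4-acetamidophenyl gives an at least 1.5-fold lower number from compound 3 to compound 4 (0.17 log units; that floor lies within the scatter), so this change has now yielded a measured value on a second core, and with a group that has no hydrogen-bond donor or acceptor. Compound 3 stands at a limit, so the true size of this step stays unknown: the limit of > 50000 nM in this assay, at which 2 of the 4 values shown sit.

The shown compounds leave open whether an unsubstituted phenyl or a 4-carboxyphenyl on this nitrogen would also give a measured value. They also cannot rank 2,5-dichlorophenyl against 3-sulfamoylphenyl, as these two groups sit on different cores.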